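The source may hold more compounds than are shown below. What is called first, only, known or untested is meant among the compounds shown, and "the series" means these compounds.

Measured compounds:
Compound 1 `O=C(Nc1ccc(F)cc1)c1cnc(N(Cc2ccccc2)Cc2ccc(B(O)O)cn2)nc1` gives 7 nM in a functional assay on RBL cells for antagonist activity at C-X-C chemokine receptor type 1 (Homo sapiens), read by fluorescence and calcium flux, with a stated time of 30 min; on this read-out lower numbers stand for stronger inhibition and higher numbers for weaker inhibition.
Compound 2 `CN(Cc1cccc(B(O)O)c1)c1ccc(C(=O)Nc2ccc(F)cc2)cn1` gives 4100 nM in this assay.
Compound 3 `O=C(Nc1ccc(F)cc1)c1ccc(N(Cc2ccccn2)Cc2ccc(B(O)O)cn2)nc1` reaches only a limit in this assay, namely > 5000 nM.

Compound 1 holds the lowest of the two numbers shown; the nearest is compound 2, whose number is far higher, well beyond the usual scatter of repeated measurements. The value of compound 3 is a limit of the assay and not a number (the limit of > 5000 nM in this assay, at which 1 of the 3 values shown sits). For the measured compounds named here, no pair of measured compounds differs in a single place, so no step between measured compounds can be read off here.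

Compound 4 `O=C(O)CN(Cc1ccc(B(O)O)cn1)c1ncc(C(=O)Nc2ccc(F)cc2)cn1` has not yet been measured. It differs from compound 1 in one place: carboxy in place of phenyl on a saturated chain carbon bound to a nitrogen on an aromatic ring. With no measured step of this kind among the compounds shown, the expectation rests on compound 1 alone. Trading a phenyl ring for a carboxy group at this place is a marked change in the shape and character of the molecule, and the step from compound 1 to compound 4 is expected to raise the number in this assay beyond the scatter, a 17-fold higher number from compound 1 to compound 4 (1.23 log units; beyond the scatter). Compound 4 is therefore estimated at 120 nM, with a likely range from 15 nM to 2000 nM.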

Compound 4, half-maximal inhibitory concentration: > 5000 nM
Compound 4 gave a limit, no number; the forecaster's own chance of this, stated with the estimate: 15%; middle value at least 41-fold (1.61 log units) away from the limit.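

In this assay, the change from benzyl to carboxymethyl on a saturated chain carbon bound to a nitrogen on an aromatic ring gives an at least 710-fold higher number from compound 1 to compound 4 (2.85 log units; beyond the scatter), a large step well beyond the scatter. For the compounds shown here, this is the first direct reading of this position, since no earlier pair of compounds differed in a single place, and it shows that inhibition here depends strongly on what stands at this place, as the rest of compound 1 is unchanged in compound 4. The result for compound 4 is a limit of the assay and not a number: the limit of > 5000 nM in this assay, at which 2 of the 4 values shown sit.

Going by these compounds alone, the single step swaps one group for another in one move, so it leaves open whether the loss of inhibition follows from removing the phenyl ring, from bringing in the carboxylic acid, or from both. An ester of the same acid, an amine on the same short chain, a plain methyl group or a longer chain ending in a phenyl ring at this place would each help to separate these possibilities.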